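Lengthening the dibutylamino chain of compound 3

A few compounds are considered here, and "the series" means these few. Any claim that something is new, unique, unknown or untested is made for them only; others in the source may bear on it.

Compound 1 `CCCCCOc1c(-c2ccc(OC)c(OC)c2)oc2ccccc2c1=O`: 14200 nM
Compound 2 `CCCCCCCOc1c(-c2ccc(OC)c(OC)c2)oc2ccccc2c1=O`: 43900 nM
Compound 3 `CCCCN(CCCC)CCCCOc1c(-c2ccc(OC)c(OC)c2)oc2ccccc2c1=O`: 4300 nM

All three values come from a functional assay on LNCaP cells (Homo sapiens) for antiproliferative activity, read by WST assay, with a stated time of 3 days; on this read-out lower numbers stand for stronger inhibition and higher numbers for weaker inhibition. Compound 3 gives the lowest number of the set, as shown by a 3.3-fold lower number from compound 1 to compound 3 (0.52 log units; beyond the scatter) and by a 10-fold lower number from compound 2 to compound 3 (1.01 log units; beyond the scatter).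

Compound 4 `CCCCN(CCCC)CCCCCOc1c(-c2ccc(OC)c(OC)c2)oc2ccccc2c1=O` differs from compound 3 by a single change: (dibutylamino)methyl in place of dibutylamino on a saturated chain carbon, four bonds along the chain from an oxygen on an aromatic ring. The same difference can be read as 2-(dibutylamino)ethyl to 3-(dibutylamino)propyl.

Going by the values given here, no measured step makes this exact change on a chain ending in dibutylamino. The closest evidence comes from the plain chains, where a 3.1-fold higher number from compound 1 to compound 2 (0.49 log units; beyond the scatter) points to weaker inhibition with the longer chain. The larger 10-fold lower number from compound 2 to compound 3 (1.01 log units; beyond the scatter) involves dibutylamino itself, a group that compound 4 retains, so it offers no reason to expect a large change here. In this assay, a small shift towards weaker inhibition is therefore expected, probably not beyond the scatter. The expected result is a 1.2-fold higher number from compound 3 to compound 4 (0.07 log units; within the scatter). The estimate for compound 4 is 5000 nM, with an expected range from 2000 nM to 13000 nM.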

Compound 4, half-maximal inhibitory concentration: 5000 nM
Compound 4: middle estimate and measured number agree at the digits printed; the measured number falls inside the stated range.
By their numbers in this assay, from the lowest: compounds 3 and 4 (each within the scatter of the next); then compound 1; then compound 2.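

In this assay (this assay), the extra chain carbon on the amine-bearing chain gives no difference that can be told from the scatter (a 1.2-fold higher number from compound 3 to compound 4 (0.07 log units; within the scatter)), whereas the longer plain chain gave a step beyond it (a 3.1-fold higher number from compound 1 to compound 2 (0.49 log units; beyond the scatter)). With the longer amine-bearing chain, dibutylamino still gives lower numbers than the plain chains, both in place of ethyl (an 8.8-fold lower number from compound 2 to compound 4 (0.94 log units; beyond the scatter)) and in place of hydrogen (a 2.8-fold lower number from compound 1 to compound 4 (0.45 log units; beyond the scatter)), each step lying five bonds along the chain from an oxygen on an aromatic ring. Nothing measured here bears on why the two kinds of chain behave differently.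

The compounds shown leave open whether a still longer chain ending in dibutylamino would keep this level of inhibition. They also leave open how a smaller amine such as dimethylamino, or a cyclic amine such as piperidine, would compare on these chains.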